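This account rests on a few compounds, and the source may have more. Where it says the series, first, only, none or still open, it means among the compounds named here.

Measured compounds:
compound 1 `CC(C)(C)c1cccc(C2CNCC2C(=O)Nc2cc3cc[nH]c(=O)c3cc2Cl)c1`: 11 nM
compound 2 `CC(C)c1cccc(C2CNCC2C(=O)Nc2cc3cc[nH]c(=O)c3cc2Cl)c1`: 6 nM
compound 3 `Cc1cccc(C2CNCC2C(=O)Nc2cc3cc[nH]c(=O)c3cc2Cl)c1`: 5 nM

In an assay on isolated protein for inhibition of Rho-associated protein kinase 2 (Homo sapiens), read by a luciferase reporter (on this read-out lower numbers stand for stronger inhibition and higher numbers for weaker inhibition), compound 3 gives the lowest of the three numbers, yet its gap to compound 2 falls within the scatter; only compound 1 stands beyond it. Compound 4 `CCc1cccc(C2CNCC2C(=O)Nc2cc3cc[nH]c(=O)c3cc2Cl)c1` differs from compound 3 by methyl in place of hydrogen on a saturated chain carbon bound to an aromatic carbon, that is, 3-methylphenyl to 3-ethylphenyl. For the measured compounds named here, the steps that bear on this are a 1.2-fold lower number from compound 2 to compound 3 (0.08 log units; within the scatter) and a 2.2-fold lower number from compound 1 to compound 3 (0.34 log units; beyond the scatter): the first within the scatter, the second modest and beyond it. Since the methyl and isopropyl analogues sit within the scatter of each other, compound 4 is expected to show no change at the digits printed from compound 3 to compound 4 (within the scatter), nothing beyond the scatter. Compound 4 is therefore estimated at 5 nM, within 3 nM to 10 nM.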

Compound 4, half-maximal inhibitory concentration: 4 nM
Compound 4: middle estimate off by 1.3-fold (0.10 log units), on the high side; measured number inside the range.
By their numbers in this assay, from the lowest: compounds 4, 3, 2 and 1 (each within the scatter of the next, the first and the last beyond it).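

In this assay the ethyl group brings no separable change at this position, with a 1.3-fold lower number from compound 3 to compound 4 (0.10 log units; within the scatter) and a 1.5-fold lower number from compound 2 to compound 4 (0.18 log units; within the scatter), so methyl, ethyl and isopropyl now read alike. Only tert-butyl stands off, with a 2.8-fold lower number from compound 1 to compound 4 (0.44 log units; beyond the scatter), although compound 1 remains within the scatter of compound 2. Taking a methyl off the saturated chain carbon reads alike on two cores: the same change on two cores in this assay, a 1.8-fold lower number (0.26 log units; within the scatter) from compound 1 to compound 2 and a 1.3-fold higher number (0.10 log units; within the scatter) from compound 4 to compound 3, 2.3-fold (0.36 log units) apart, within the scatter of two such steps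

The compounds shown leave open whether this tolerance holds for an amine, a carboxylic acid or a methoxy group at this position.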